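The source may hold more compounds than are shown below. What is called first, only, known or untested is meant among the compounds shown, and "the series" means these compounds.

Compound 2 `CNC(=O)[C@H]1O[C@@H](n2cnc3c(NCc4cc(Cl)ccc4OCC(=O)O)ncnc32)[C@H](O)[C@@H]1N` gives 130 nM in an assay on isolated protein for binding affinity to adenosine receptor A3 (Homo sapiens) (on this read-out higher numbers stand for weaker inhibition and lower numbers for stronger inhibition), the higher of the two numbers measured here; its nearest neighbour, compound 1 `CNC(=O)[C@H]1O[C@@H](n2cnc3c(NCc4cc(Cl)ccc4OCc4ccccc4)ncnc32)[C@H](O)[C@@H]1N`, gives 16 nM. For the measured compounds named here, the one measured step, an 8.1-fold higher number from compound 1 to compound 2 (0.91 log units; beyond the scatter), lies elsewhere in the molecule. Compound 3 `CNC(=O)[C@H]1O[C@@H](n2cnc3c(NCc4cc(Cl)ccc4OCC(N)=O)ncnc32)[C@H](O)[C@@H]1N` instead changes the group on a carbonyl carbon: amino in place of hydroxy on a carbonyl carbon. Going by the values given here, no measured step bears directly on this change, so the expectation rests on compound 2 alone. A small step, a 2.2-fold lower number from compound 2 to compound 3 (0.34 log units; beyond the scatter), is expected, toward a somewhat lower number. Compound 3 is estimated at 60 nM, with a range from 20 nM to 180 nM.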

Compound 3, inhibition constant: 6.8 nM
Compound 3: the middle estimate sits 8.8-fold (0.95 log units) above what was measured; the whole stated range lies above it.
By their numbers in this assay, from the lowest: compound 3; then compound 1; then compound 2.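

Replacing hydroxy with amino on this carbonyl carbon leaves the counts of heavy atoms and hydrogen-bond donors unchanged, yet it gives a 19-fold lower number from compound 2 to compound 3 (1.28 log units; beyond the scatter) in this assay, so this position responds strongly to a one-atom swap. The carbamoyl group also compares well with phenyl at the same place, with a 2.4-fold lower number from compound 1 to compound 3 (0.37 log units; beyond the scatter), so a phenyl ring is not required there for a low number. Going by these compounds, whether a methyl ester or a methylamino group on this carbonyl carbon would keep that low number remains open. No supporting data explain the size of these steps.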